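Nitro for methoxy on the thiourea aryl ring

The compounds below may be only part of what the source reports. "The series", "measured", "known", "first", "only" and "open" are said of these compounds alone.

Measured compounds:
compound 1, `COc1cccc(NC(=S)NC2CC(C)(C)Oc3ccc(Br)cc32)c1`, 87000 nM
compound 2, `CC1(C)CC(NC(=O)NCc2ccccc2)c2cc(Br)ccc2O1`, 38000 nM

Two compounds sharing the same core were tested in a functional assay on T98G cells (Homo sapiens) for inhibition, read by MTT assay, with a stated time of 72 h; on this read-out higher numbers stand for weaker inhibition and lower numbers for stronger inhibition. Compound 1 stands at the highest of the two numbers; the nearest is compound 2, whose number is lower by an amount beyond the usual scatter. Within the data shown here, both compounds are weak inhibitors on this read-out, and no pair differing in a single place has been measured, so no step is known.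

Compound 3, `CC1(C)CC(NC(=S)Nc2cccc([N+](=O)[O-])c2)c2cc(Br)ccc2O1`, is the unmeasured compound. It differs from compound 1 in one place: nitro in place of methoxy on an aromatic carbon. Among the measured compounds shown here, there is no measured step of this kind to lean on, so any expectation rests on compound 1 alone, with 87000 nM as the anchor. A small step, in either direction and probably not beyond the scatter, is expected in this assay; the estimated step is a 1.5-fold lower number from compound 1 to compound 3 (0.16 log units; within the scatter). The estimate for compound 3 in this assay is 60000 nM, with a range from 20000 nM to 180000 nM.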

Compound 3, half-maximal inhibitory concentration: 4000 nM
For compound 3 the middle estimate is 15-fold (1.18 log units) above the measured one, outside the stated range (below it).
By their numbers in this assay, from the lowest: compound 3; then compound 2; then compound 1.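

In this assay, the aromatic carbon that carries the methoxy group in compound 1 proves to be a sensitive place on the molecule: nitro in place of methoxy gives a 22-fold lower number from compound 1 to compound 3 (1.34 log units; beyond the scatter) and so moves the read-out far beyond the usual scatter. Compound 1 and compound 2 differ in more than one place, so they could not tie any change in the number to a single group, whereas this pair ties a large change to this one substitution on the thiourea aryl ring, at the place meta to a large group, with the rest of the molecule unchanged. The data shown offer no measurement that accounts for the size of this step, and a single pair gives no sign of whether it follows any trend across substituents.

The compounds shown leave open how other groups would behave at this same place, such as an amine, a nitrile or a carboxylic acid, and whether any of them would come near compound 3 at 4000 nM in this read-out. They also leave open whether nitro would give a step of similar size on another carbon of the same ring, or on a urea in place of the thiourea.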